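A Hydroxyphenyl Gives Way to a Hydroxypyridyl Group

The compounds below may be only part of what the source reports. "The series", "measured", "known", "first", "only" and "open" are said of these compounds alone.

Of the compounds shown here, three have been tested in a functional assay on HEK293 cells for agonist activity at D(4) dopamine receptor (Homo sapiens), read by FLIPR; on this read-out lower numbers stand for smaller maximal responses and higher numbers for larger maximal responses. Compound 1 `Cc1cccc(NC(=O)CN2CCC(c3ccc(O)cc3)CC2)c1` gives 60% in this assay. Compound 2 `CSc1cccc(NC(=O)CN2CCC(c3cccc[n+]3[O-])CC2)c1` gives 56%, and compound 3 `O=C(NCN1CCC(c2cccc[n+]2[O-])CC1)c1ccc2ccccc2c1` gives 67%. The number for compound 1 lies between those of compound 2 and compound 3, and each of those two numbers sits within the usual scatter of it, so the three compounds cannot be told apart by this read-out.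

Compound 4 `Cc1cccc(NC(=O)CN2CCC(c3ccc(O)cn3)CC2)c1` has not been measured yet. It differs from compound 1 in one place: 5-hydroxypyridin-2-yl in place of 4-hydroxyphenyl on a saturated ring carbon. Within the data shown here, the groups that leave and enter are of the same size, and both carry a hydroxyl; the only change is a ring nitrogen in place of a ring carbon. Since compounds 2 and 3, which also carry a nitrogen-bearing ring at this position, give numbers indistinguishable from compound 1, the step expected from compound 1 to compound 4 in this assay is a number 2 percentage points lower from compound 1 to compound 4 (within the scatter), that is, none beyond the scatter. Compound 4 is therefore estimated to give 58%, with a likely range from 42% to 74%.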

Compound 4, largest response reached (reported as efficacy), in percent of the reference or control that the assay uses: 83%
Estimate against measurement, compound 4: 25 percentage points below; measured number above the stated range.
By their numbers in this assay, from the lowest: compounds 2, 1 and 3 (each within the scatter of the next, the first and the last beyond it); then compound 4.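

In this assay, among these compounds, the step of a number 23 percentage points higher from compound 1 to compound 4 (beyond the scatter) is the first here that stands clear of the scatter, so this place on the saturated ring does respond to a change. Putting one ring nitrogen in place of one ring carbon, while the hydroxyl stays, is enough to produce it; compound 2 and compound 3 could not show this, as each differs from compound 1 in more than one place. Nothing available explains why the ring nitrogen goes with the larger maximal response.

Still open, from the compounds shown here alone, is whether the hydroxyl is needed for this step, which a methoxy group or an amine in its place on the same pyridine ring would test. Going by these compounds, it is also open whether the same swap gives a similar step with a different group on the amide.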